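Swapping a Thienyl Arm for a Pyridyl Arm

The source may hold more compounds than are shown below. What is called first, only, known or untested is meant among the compounds shown, and "the series" means these compounds.

Compound 1 `Oc1ccc(-c2cc(-c3ccc(Cl)cc3)nc(-c3ccsc3)c2)cc1` gives 47.7% in an assay on isolated protein for inhibition of DNA topoisomerase 1 (Homo sapiens), with a stated time of 30 min, tested at 100 uM (a lower number here means a weaker effect, a higher number a stronger effect of the compound at the concentration tested), the highest of the three numbers recorded. Compound 2 `Oc1cccc(-c2cc(-c3ccc(Cl)cc3)nc(-c3ccsc3)c2)c1` gives 11.7% and compound 3 `Oc1ccc(-c2cc(-c3ccsc3)nc(-c3ccccc3Cl)c2)cc1` gives 4.1%. The two measured steps, a number 36 percentage points lower from compound 1 to compound 2 (beyond the scatter) and a number 43.6 percentage points lower from compound 1 to compound 3 (beyond the scatter), are both large and both concern a phenyl substituent. Compound 4 `Oc1ccc(-c2cc(-c3ccncc3)nc(-c3ccc(Cl)cc3)c2)cc1` differs from compound 1 in another place: pyridin-4-yl in place of thiophen-3-yl on an aromatic carbon. Neither measured step touches the thiophen-3-yl group, so they give no direct guide to the size or direction of this change, only the observation that every alteration so far made to compound 1 lowered the read-out sharply. Compound 4 is therefore expected to show a moderate loss, a number 14.7 percentage points lower from compound 1 to compound 4 (beyond the scatter), at an estimated 33% within 5% to 60%.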

Compound 4, a percentage reported as inhibition, at one concentration (the size of the read-out at that concentration, not a potency): 5.9%
Estimate against measurement, compound 4: 27.1 percentage points above, within the range that was stated.
By their numbers in this assay, from the lowest: compounds 3, 4 and 2 (each within the scatter of the next); then compound 1.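

For the compounds shown here, the place next to the ring nitrogen, untouched by the earlier steps, also responds strongly in this assay: pyridin-4-yl in place of thiophen-3-yl gives a number 41.8 percentage points lower from compound 1 to compound 4 (beyond the scatter). The thiophen-3-yl group is therefore not a freely exchangeable part of compound 1, at least for this replacement. No measurement shown here bears on what lies behind this loss.

On these data alone, whether the outcome follows from the six-membered ring or from the location of its nitrogen remains open. A plain phenyl or a pyridin-3-yl group at this position would help separate the two.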